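The source may hold more compounds than are shown below. What is called first, only, known or untested is meant among the compounds shown, and "the series" means these compounds.

Compound 1 `O=C(N/N=C/c1ccc(F)cc1)Nc1ccc(Oc2ccnc3[nH]ccc23)cc1`: 3430 nM
Compound 2 `CCN(CC)CCn1cccc1/C=N/NC(=O)Nc1ccc(Oc2ccnc3[nH]ccc23)cc1`: 5880 nM

In a functional assay on HepG2 cells (Homo sapiens) for antiproliferative activity, read by MTT assay, with a stated time of 72 h (a higher number here means a weaker inhibitor, a lower number a stronger inhibitor), compound 2 gives 5880 nM, which lies within the scatter of compound 1 at 3430 nM. Compound 3 `CN(C)CCCn1cccc1/C=N/NC(=O)Nc1ccc(Oc2ccnc3[nH]ccc23)cc1` keeps the rest of compound 2 and carries one change: (dimethylamino)methyl in place of diethylamino on a saturated chain carbon, two bonds along the chain from an aromatic nitrogen. Cut one bond further out, this reads 2-(diethylamino)ethyl to 3-(dimethylamino)propyl. For the measured compounds named here, no measured pair shows what such a change does, so no shift beyond the scatter is expected, and the estimated step of a 1.3-fold lower number from compound 2 to compound 3 (0.12 log units; within the scatter) stays within it. The expected value for compound 3 is 4500 nM, with an estimated range of 1800 nM to 11000 nM.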

Compound 3, half-maximal inhibitory concentration: 4190 nM
Beside the measured number, compound 3's estimate is 1.1-fold (0.03 log units) above it; the range from low to high includes it.
By their numbers in this assay, from the lowest: compounds 1, 3 and 2 (each within the scatter of the next).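

In this assay, for the compounds shown here, the pair that changes only this chain gives a first reading of the exchange: 3-(dimethylamino)propyl in place of 2-(diethylamino)ethyl gives a 1.4-fold lower number from compound 2 to compound 3 (0.15 log units; within the scatter), so this difference in the amine chain leaves the number inside the scatter. With 1-(3-(dimethylamino)propyl)-1H-pyrrol-2-yl in place of 4-fluorophenyl, the step is a 1.2-fold higher number from compound 1 to compound 3 (0.09 log units; within the scatter), also inside the scatter. Nothing at hand explains either step. The compounds shown leave open whether a morpholine, a carboxylic acid or a longer chain at this position would move the number beyond the scatter.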